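Indole Swap on a Hydroxamate Piperidine Scaffold

The source may hold more compounds than are shown below. What is called first, only, known or untested is meant among the compounds shown, and "the series" means these compounds.

Three hydroxamic acids were examined in a functional assay on SW480 cells (Homo sapiens) for antiproliferative activity, with a stated time of 72 h; on this read-out higher numbers stand for weaker inhibition and lower numbers for stronger inhibition. Within the data shown here, compound 1 `O=C(COc1ccc(CN2CC=C(c3c[nH]c4ccc(F)cc34)CC2)c(F)c1)NO` carries a 5-fluoro-1H-indol-3-yl group and a benzylic link to the piperidine ring; in this assay compound 1 gives 3860 nM, the only finite number among the three. Compound 3 `O=C(COc1ccc(C(=O)N2CC=C(c3c[nH]c4ccc(F)cc34)CC2)cc1)NO` joins the same indole to the piperidine through a carbonyl instead; in this assay compound 3 reaches only the limit of > 5000 nM. Compound 2 `Cc1[nH]c2ccccc2c1C1=CCN(C(=O)c2ccc(OCC(=O)NO)cc2)CC1` differs from compound 3 by 2-methyl-1H-indol-3-yl in place of 5-fluoro-1H-indol-3-yl on a double-bonded ring carbon. In this assay compound 2 likewise stops at the limit of > 5000 nM. The resulting step, a step that the two limits leave unreadable from compound 3 to compound 2, cannot be sized because the limit of > 5000 nM in this assay, at which 2 of the 3 values shown sit, holds both ends of the pair. The difference between the cores of compound 1 and compound 3 is not broken down here.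

Compound 4 `Cc1[nH]c2ccccc2c1C1=CCN(Cc2ccc(OCC(=O)NO)cc2F)CC1` has not yet been measured. It stands to compound 1 as compound 2 stands to compound 3: 2-methyl-1H-indol-3-yl in place of 5-fluoro-1H-indol-3-yl on a double-bonded ring carbon, the same change at the same place, its second occurrence among these compounds. Among the measured compounds shown here, the one measured instance of this change gives no readable size, so the expectation can lean only on the finite starting point. Because compound 1 gives 3860 nM in this assay, the step expected for compound 4 is a 1.3-fold higher number from compound 1 to compound 4 (0.11 log units; within the scatter). Compound 4 is therefore estimated at 5000 nM in this assay, with a likely range from 1800 nM to 14000 nM, and a real chance that only a limit is reported.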

Compound 4, half-maximal inhibitory concentration: 1600 nM
The estimate for compound 4 lay 3.1-fold (0.49 log units) above the measured number; the whole stated range lies above it.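

In this assay, placing 2-methyl-1H-indol-3-yl where 5-fluoro-1H-indol-3-yl stood on the core of compound 1 gives a 2.4-fold lower number from compound 1 to compound 4 (0.38 log units; beyond the scatter), so on this core the change has a readable size and points toward stronger inhibition. The same change on the carbonyl-linked core offers no size to set beside this one, and the step from compound 3 to compound 2 cannot be read, because both of its ends sit at a limit: the limit of > 5000 nM in this assay, at which 2 of the 4 values shown sit.

The result therefore shows the effect of the change on one core only; it does not show that the change carries from one core to the other, either in size or in direction, and it offers no explanation for the lower number.

Open, going by these compounds, is how much of the step belongs to the entering 2-methyl group and how much to the departing 5-fluoro group, a question that an unsubstituted 1H-indol-3-yl group on the core of compound 1 would address. Also open, on these data alone, is how the number would respond on either core if a carboxylic acid stood in place of the hydroxamic acid, or if a longer chain carried it.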